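The source may report more compounds than this note shows. Statements on the series, on what has been measured and on what is new or still open speak of the compounds shown alone.

Measured so far in an ADME assay on Vero cells (Chlorocebus sabaeus) for inhibition, read by sulforhodamine B assay, with a stated time of 48 h; a lower number here means a stronger inhibitor of growth, a higher number a weaker inhibitor of growth:
Compound 1 `CC1=CC[C@H](C(C)(C)N=C=S)CC1`: compound 1 gives > 100000 nM, which is a limit of the assay.
Compound 2 `COc1ccc(/C=N/NC(=S)NC(C)(C)[C@H]2CC=C(C)CC2)cc1`: compound 2 gives 70100 nM.
Compound 3 `CC1=CC[C@H](C(C)(C)NC(=S)N/N=C/c2cccc([N+](=O)[O-])c2)CC1`: compound 3 gives > 100000 nM, which is a limit of the assay.

Compound 2 is the only one of the three that yields a number in this assay at all. Compound 1 and compound 3 stop at the limit of > 100000 nM in this assay, at which 2 of the 3 values shown sit, so for them only a limit is reported and no number. Within the data shown here, whether compound 2 is stronger or weaker than those two cannot be read from a limit; it is simply the one value that can be placed on the scale.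

Compound 4 `CC1=CC[C@H](C(C)(C)NC(=S)N/N=C/c2cccs2)CC1` has not yet been measured. It differs from compound 2 in one place: thiophen-2-yl in place of 4-methoxyphenyl on a carbon with a double bond to nitrogen. Among the measured compounds shown here, no step between two measured compounds is available to show what such a change does here, and the pair compound 2 and compound 3 shows only one number and one limit.

With nothing to lean on, the expected step for compound 4 is a 1.2-fold higher number from compound 2 to compound 4 (0.08 log units; within the scatter), essentially none beyond the usual scatter. Compound 4 is estimated at 85000 nM, with a range from 40000 nM to 200000 nM, and a fair chance that this assay reports only a limit for it.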

Compound 4, concentration for total growth inhibition: 13400 nM
Estimate against measurement, compound 4: 6.3-fold (0.80 log units) above; measured number outside the range, below it.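

In this assay, the group on the carbon with a double bond to nitrogen now has a step that can be read between two real numbers: thiophen-2-yl in place of 4-methoxyphenyl gives a 5.2-fold lower number from compound 2 to compound 4 (0.72 log units; beyond the scatter). This step lies beyond the usual scatter, so this position is not a silent one, and what sits there changes how strongly these compounds inhibit growth. In this change, a six-membered aromatic ring of carbon only gives way to a five-membered aromatic ring with 1 hetero atom, while the counts of hydrogen-bond donors and acceptors stay the same, so those counts do not separate the two groups.

From the compounds shown here alone, compound 3 still gives only a limit, so its place on the scale relative to compound 2 and compound 4 stays open: the limit of > 100000 nM in this assay, at which 2 of the 4 values shown sit. Nor can this single step tell whether the smaller ring, the sulfur atom or the loss of the methoxy group matters most; a plain phenyl or a furan-2-yl ring at this place would be needed to pull those apart.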